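A few compounds are considered here, and "the series" means these few. Any claim that something is new, unique, unknown or untested is made for them only; others in the source may bear on it.

Compound 1, `COc1cc(-c2cc(C(=O)O)c3ccccc3n2)ccc1OCC(=O)Nc1ccccc1`, in an ADME assay on HaCaT cells (Homo sapiens) for inhibition (a lower number here means a stronger inhibitor, a higher number a weaker inhibitor), gives only a limit of the assay, > 300000 nM.
Compound 2, `COc1cc(-c2cc(C(=O)O)c3ccccc3n2)ccc1OCC(=O)Nc1ccccc1C`, gives 230000 nM.
Compound 3, `COc1cc(-c2cc(C(=O)O)c3ccccc3n2)ccc1OCC(=O)Nc1ccccc1F`, gives 161000 nM.

Among these, compound 3 and compound 2 give numbers that sit within the usual scatter of each other (a 1.4-fold lower number from compound 2 to compound 3 (0.15 log units; within the scatter)), while compound 1 offers a limit rather than a number. Compound 4, `COc1cc(-c2cc(C(=O)O)c3ccccc3n2)ccc1OCC(=O)Nc1ccc(F)cc1`, differs from compound 3 by 4-fluorophenyl in place of 2-fluorophenyl on an amide-type nitrogen. The steps measured so far put a group onto a ring that had none there: an at least 1.3-fold lower number from compound 1 to compound 2 (0.11 log units; that floor lies within the scatter) and an at least 1.8-fold lower number from compound 1 to compound 3 (0.27 log units; that floor lies within the scatter), both floors within the scatter. None of them moves a fluoro from one place on the ring to another, so no step beyond the scatter is expected here, a 1.1-fold higher number from compound 3 to compound 4 (0.02 log units; within the scatter). Compound 4 is therefore estimated at 170000 nM, between 80000 nM and 350000 nM.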

Compound 4, half-maximal inhibitory concentration: 286000 nM
For compound 4 the middle estimate is 1.7-fold (0.23 log units) below the measured one; the range from low to high includes it.
By their numbers in this assay, from the lowest: compounds 3, 2 and 4 (each within the scatter of the next). At a limit, above all of these: compound 1.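

Moving the fluoro, 2-fluorophenyl to 4-fluorophenyl on the amide-type nitrogen, gives a 1.8-fold higher number from compound 3 to compound 4 (0.25 log units; within the scatter), so at this position its place on the ring shows no effect that can be told from noise. The swap of 2-methylphenyl for 4-fluorophenyl gives a 1.2-fold higher number from compound 2 to compound 4 (0.09 log units; within the scatter), likewise no real difference. The step from compound 1, an at least 1.0-fold lower number from compound 1 to compound 4 (0.02 log units; that floor lies within the scatter), cannot be read as a size, since compound 1 gives only a limit: the limit of > 300000 nM in this assay, at which 1 of the 4 values shown sits.

From the compounds shown here alone, whether an amine or a carboxylic acid on this ring would give a step beyond the scatter stays open.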